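Pendant aryl substituent exchange in the cyclopropanecarboxamide series

A few compounds are considered here, and "the series" means these few. Any claim that something is new, unique, unknown or untested is made for them only; others in the source may bear on it.

Compound 2 `COc1cccc(-c2ccc(N(C[C@@H](N)CC(C)C)C(=O)[C@@H]3C[C@H]3c3ccccc3)cc2)c1` gives 1100 nM in a functional assay for agonist activity at G protein-coupled receptor 88 (Homo sapiens), read by HTRF and cAMP accumulation; a higher number here means that more compound is needed for the effect, a lower number that less compound is needed. The other measured member, compound 1 `CC(C)C[C@H](N)CN(C(=O)[C@@H]1C[C@H]1c1ccccc1)c1ccc(-c2cccnc2)cc1`, gives 10000 nM in this assay. Among the measured compounds shown here, the single step measured so far, a 9.1-fold lower number from compound 1 to compound 2 (0.96 log units; beyond the scatter), corresponds to 3-methoxyphenyl in place of pyridin-3-yl on an aromatic carbon, and leaves compound 2 with the lowest of the two numbers.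

Compound 3 `CC(C)C[C@H](N)CN(C(=O)[C@@H]1C[C@H]1c1ccccc1)c1ccc(-c2cccc(C#N)c2)cc1` has not yet been measured. It differs from compound 2 by cyano in place of methoxy on an aromatic carbon. For the measured compounds named here, no measured step exchanges one small group for another on the pendant phenyl: the only step available replaced the whole pendant ring, so it bears on this change only loosely and sets no direction. With both groups counting one hydrogen-bond acceptor and no ring, the working expectation is a step in this assay that stays within the scatter or moves to a slightly higher number. Compound 3 is therefore expected to give about 1600 nM, with a range from 500 nM to 5000 nM. The expected step is a 1.5-fold higher number from compound 2 to compound 3 (0.16 log units; within the scatter).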

Compound 3, half-maximal effective concentration: 4500 nM
Beside the measured number, compound 3's estimate is 2.8-fold (0.45 log units) below it; measured number inside the range.
By their numbers in this assay, from the lowest: compound 2; then compound 3; then compound 1.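

Exchange of one small group on the pendant phenyl is not neutral in this assay: cyano in place of methoxy, meta to a large group, gives a 4.1-fold higher number from compound 2 to compound 3 (0.61 log units; beyond the scatter), although the two groups match in heavy-atom count and hydrogen-bond acceptor count and neither carries a ring or a net charge. The pendant ring change therefore cannot be read apart from the group it carries: 3-cyanophenyl in place of pyridin-3-yl still gives a 2.2-fold lower number from compound 1 to compound 3 (0.35 log units; beyond the scatter), while 3-methoxyphenyl in the same place gives a 9.1-fold lower number from compound 1 to compound 2 (0.96 log units; beyond the scatter), and compound 2 and compound 3 stand apart beyond the scatter. Nothing available accounts for the difference between methoxy and cyano at this position.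

As far as these compounds go, whether methoxy holds a particular advantage or cyano a particular penalty stays open, and a hydroxyl group, an amine, a fluorine atom or an ethoxy group on the same aromatic carbon would help separate the two readings. The compounds shown also leave open whether the step between these two groups carries over when they sit elsewhere on the pendant phenyl.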